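A Tetrazolyl Group Added to Compound 2

The compounds below may be only part of what the source reports. "The series", "measured", "known", "first", "only" and "open" are said of these compounds alone.

Two measured compounds share a core built around a sulfonamide carrying a trifluoromethyl group and a phenylsulfonyl group. In an assay on U2OS cells for inhibition of secreted frizzled-related protein 1 (Homo sapiens), read by a luciferase reporter, with a stated time of 18 h (on this read-out higher numbers stand for an effect only at larger amounts of compound and lower numbers for an effect already at smaller amounts), compound 1 `O=C(c1ccc(Cl)cc1)N1CCC(NS(=O)(=O)c2cc(S(=O)(=O)c3ccccc3)ccc2C(F)(F)F)CC1` gives 1800 nM. Compound 2 `O=S(=O)(NC1CCN(S(=O)(=O)c2ccccc2)CC1)c1cc(S(=O)(=O)c2ccccc2)ccc1C(F)(F)F` gives 210 nM in this assay. The single measured step is an 8.6-fold lower number from compound 1 to compound 2 (0.93 log units; beyond the scatter), and it leaves compound 2 with the lowest of the two numbers shown, compound 1 being its only neighbour.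

Compound 3 `O=S(=O)(NC1CCN(S(=O)(=O)c2cccc(-c3nnn[nH]3)c2)CC1)c1cc(S(=O)(=O)c2ccccc2)ccc1C(F)(F)F` differs from compound 2 by 1H-tetrazol-5-yl in place of hydrogen on an aromatic carbon. Going by the values given here, no measured step touches this ring position. Among the compounds with values here, the only step at hand exchanged the whole group on the ring nitrogen rather than adding to it, so it bears on the new change only loosely and gives no direction. Within the data shown here, with no closer precedent, the step of a 1.2-fold higher number from compound 2 to compound 3 (0.08 log units; within the scatter) is expected to remain within or near the scatter. Compound 3 is therefore estimated to give about 250 nM in this assay, with a range from 80 nM to 900 nM.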

Compound 3, half-maximal effective concentration: 1200 nM
Estimate against measurement, compound 3: 4.8-fold (0.68 log units) below; the whole stated range lies below it.
By their numbers in this assay, from the lowest: compound 2; then compounds 3 and 1 (each within the scatter of the next).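

Adding to this ring is not neutral. In this assay, the change from phenyl to 3-(1H-tetrazol-5-yl)phenyl gives a 5.7-fold higher number from compound 2 to compound 3 (0.76 log units; beyond the scatter), so a single group on an aromatic carbon of the ring is enough to move the number beyond the scatter. The earlier step, an 8.6-fold lower number from compound 1 to compound 2 (0.93 log units; beyond the scatter), exchanged the whole group on the ring nitrogen and could only show that the phenylsulfonyl group goes with the lower number; this result shows that the number also responds to a change made within that group, and that the added 1H-tetrazol-5-yl goes with a higher number here. Nothing at hand accounts for this rise.

With only one substituent shown at this place, it remains open whether the rise belongs to the 1H-tetrazol-5-yl group in particular or would come with other groups on the same carbon, such as a carboxylic acid, a nitrile or a methyl group. From the compounds shown here alone, it also remains open whether 1H-tetrazol-5-yl on a different carbon of this ring would give a similar step.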